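Swapping an Isopropyl Branch for a Carbamoylmethyl Group

The compounds below may be only part of what the source reports. "The series", "measured", "known", "first", "only" and "open" are said of these compounds alone.

Within the data shown here, compound 2 `CC(C)C[C@H](NC(=O)CN(c1nc(Cl)nc2[nH]cnc12)C1CC1)C(=O)O` is one of two compounds measured in a functional assay on the whole organism (Tail, strain ICR) with Mus musculus as the target, in the tail flick test, with a stated time of 60 min, at a dose of 25 umol/kg by the oral route; on this read-out lower numbers stand for a weaker effect and higher numbers for a stronger effect at the one dose given. In this assay compound 2 gives 36.4%. Its closest relative is compound 1 `CC[C@H](C)[C@H](NC(=O)CN(c1nc(Cl)nc2[nH]cnc12)C1CC1)C(=O)O`, which in this assay gives 36%. Among the measured compounds shown here, the one measured step, a number 0.4 percentage points higher from compound 1 to compound 2 (within the scatter), is within the scatter, so compound 2 stands highest of the two numbers only on paper, and the two cannot be told apart.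

Compound 3 `NC(=O)CC[C@H](NC(=O)CN(c1nc(Cl)nc2[nH]cnc12)C1CC1)C(=O)O` has not yet been measured. It differs from compound 2 by carbamoylmethyl in place of isopropyl on a saturated chain carbon, two bonds along the chain from an amide-type nitrogen and a carbonyl carbon. For the measured compounds named here, the only step available for comparison is the small one from compound 1 to compound 2, where one saturated branch replaced another of the same size without a change beyond the scatter. The change to compound 3 is of a different kind, since a carbamoylmethyl group enters where an isopropyl group leaves, so that step gives little guidance. The expectation is therefore a step in this assay of a number 6.4 percentage points lower from compound 2 to compound 3 (within the scatter), with wide uncertainty in either direction. Compound 3 is estimated to give 30%, expected to fall between 8% and 55%.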

Compound 3, a percentage reported as activity, at one dose (the size of the read-out at that dose, not a potency): 38.4%
For compound 3 the middle estimate is 8.4 percentage points below the measured one, and the stated range covers the measured number.
By their numbers in this assay, from the lowest: compounds 1, 2 and 3 (each within the scatter of the next).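

Among these compounds, until now, the only change at this position was one saturated branch for another of the same size. Compound 3 goes further, placing carbamoylmethyl, which carries nitrogen and oxygen and has a hydrogen-bond donor and acceptor, where isopropyl stood on the saturated chain carbon, and this assay shows a number 2 percentage points higher from compound 2 to compound 3 (within the scatter). Set against the other branched chain, 2-carbamoylethyl in place of sec-butyl gives a number 2.4 percentage points higher from compound 1 to compound 3 (within the scatter), so even this different kind of side chain cannot be told apart from the two saturated ones on this read-out, and the data offer no explanation for why these side chains read alike.

Still open, as far as these compounds go, is whether any group at this position can move the number beyond the scatter, for example a side chain ending in an amine or a carboxylic acid, a longer chain, or one bearing a phenyl ring. Also open, from the compounds shown here alone, is whether compounds 1, 2 and 3 remain indistinguishable at other doses or times, since this assay reports a single dose at a single stated time.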